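Replacing Methoxy with Phenyl in Compound 2

The source may hold more compounds than are shown below. What is called first, only, known or untested is meant among the compounds shown, and "the series" means these compounds.

Compound 1 `Cc1ccc(S/C(=C/c2ccc(Oc3ccccc3)cc2)C(=O)c2ccc(Cl)cc2)cc1`: 10000 nM
Compound 2 `COc1ccc(/C=C(/Sc2ccc(C)cc2)C(=O)c2ccc(Cl)cc2)cc1`: 1000 nM

In a functional assay on DU-145 cells (Homo sapiens) for inhibition, read by trypan blue exclusion, with a stated time of 96 h (on this read-out lower numbers stand for stronger inhibition of growth and higher numbers for weaker inhibition of growth), compound 2 gives the lower of the two numbers, 1000 nM. Compound 3 `Cc1ccc(S/C(=C/c2ccc(-c3ccccc3)cc2)C(=O)c2ccc(Cl)cc2)cc1` differs from it in one place: phenyl in place of methoxy on an aromatic carbon. For the measured compounds named here, one measured step bears on this change, a 10-fold lower number from compound 1 to compound 2 (1.00 log units; beyond the scatter), with methyl in place of phenyl on an oxygen on an aromatic ring. Compound 3 again carries a phenyl, though without that oxygen, so a higher number is expected, going by compound 1 at 10000 nM. The expected change is a 4.0-fold higher number from compound 2 to compound 3 (0.60 log units; beyond the scatter). For compound 3 the estimated value is 4000 nM, with an expected range of 1200 nM to 15000 nM.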

Compound 3, concentration for 50% growth inhibition: 50000 nM
Compound 3: middle estimate off by 13-fold (1.10 log units), on the low side; the whole stated range lies below it.
By their numbers in this assay, from the lowest: compound 2; then compound 1; then compound 3.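

In this assay, phenyl on this aromatic carbon gives the highest number of the three groups, with a 50-fold higher number from compound 2 to compound 3 (1.70 log units; beyond the scatter), a larger step than the earlier change from phenoxy to methoxy. The oxygen of the phenoxy group also counts, since its loss gives a 5.0-fold higher number from compound 1 to compound 3 (0.70 log units; beyond the scatter), so size alone does not order these compounds. Nothing measured here accounts for this order. Going by these compounds, whether a hydroxyl, an amine or an ethoxy group on this carbon would fall nearer compound 2 or compound 3 remains open.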